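The compounds below may be only part of what the source reports. "The series", "measured", "known", "first", "only" and "open" are said of these compounds alone.

Measured in an assay on Huh-7 cells for agonist activity at Bile acid receptor (Homo sapiens), read by a luciferase reporter; on this read-out lower numbers stand for an effect already at smaller amounts and higher numbers for an effect only at larger amounts of compound:
compound 1, `CCCC(CCC)n1c(-c2ccc(OCc3c(-c4c(Cl)cccc4Cl)noc3C(C)C)cc2)nc2ccc(C(=O)O)cc21`, gives 1.8 nM
compound 2, `CC(C)c1onc(-c2c(Cl)cccc2Cl)c1COc1ccc(-c2nc3ccc(C(=O)O)cc3n2C)c(Cl)c1`, gives 3.66 nM
compound 3, `CC(C)c1onc(-c2c(Cl)cccc2Cl)c1COc1ccc(-c2nc3ccc(C(=O)O)cc3n2C)cc1Cl`, gives 19 nM

Among these three numbers compound 1 stands lowest in this assay; compound 2 comes nearest to it and compound 3 lies furthest, both beyond the usual scatter. Compound 4, `CC(C)c1onc(-c2c(Cl)cccc2Cl)c1COc1ccc(-c2nc3ccc(C(=O)O)cc3n2C2CCC2)cc1`, has not yet been measured in this assay. It differs from compound 1 in a single place: cyclobutyl in place of 1-propylbutyl on an aromatic nitrogen. Among the measured compounds shown here, compounds 2 and 3 each differ from compound 1 in more than one place, so no measured step isolates this particular change. On that basis a modest move toward higher numbers is expected, a 2.8-fold higher number from compound 1 to compound 4 (0.44 log units; beyond the scatter). Compound 4 is accordingly estimated at 5 nM, with a likely range from 1.5 nM to 20 nM.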

Compound 4, half-maximal effective concentration: 14.4 nM
Beside the measured number, compound 4's estimate is 2.9-fold (0.46 log units) below it, within the range that was stated.
By their numbers in this assay, from the lowest: compound 1; then compound 2; then compounds 4 and 3 (each within the scatter of the next).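

In this assay, the group on the aromatic nitrogen matters on its own: cyclobutyl in place of 1-propylbutyl brings an 8.0-fold higher number from compound 1 to compound 4 (0.90 log units; beyond the scatter). Among the compounds shown here, this is the first change isolated at this position, and the number rises as 7 carbons give way to 4 in a ring. No available evidence explains this step.

As far as these compounds go, whether the ring or the smaller carbon count goes with the higher number stays open, as this one pair changes both together. A cyclohexyl ring or an unbranched butyl chain on this nitrogen would help separate the two.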